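Exchange of the isopentylsulfanyl group for a substituted phenyl ring

The compounds below may be only part of what the source reports. "The series", "measured", "known", "first", "only" and "open" are said of these compounds alone.

Measured so far in an assay on CHO cells for antagonist activity at transient receptor potential cation channel subfamily V member 1 (Homo sapiens), read by FLIPR; on this read-out lower numbers stand for stronger inhibition and higher numbers for weaker inhibition:
compound 1 `CC(C(=O)NCc1ccc(C(F)(F)F)cc1N1CCCCCC1)c1ccc(NS(C)(=O)=O)c(F)c1` gives 1.6 nM
compound 2 `CC(C(=O)NCc1ccc(C(F)(F)F)cc1OCc1ccc(F)cc1)c1ccc(NS(C)(=O)=O)c(F)c1` gives 0.5 nM
compound 3 `CC(C)CCSc1cc(C(F)(F)F)ccc1CNC(=O)C(C)c1ccc(NS(C)(=O)=O)c(F)c1` gives 1.4 nM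

Compound 3 holds the second highest of the three numbers. Its nearest neighbour is compound 1, with a 1.1-fold lower number from compound 1 to compound 3 (0.06 log units; within the scatter), so the two cannot be told apart. Compound 2 stands furthest away, with a 2.8-fold higher number from compound 2 to compound 3 (0.45 log units; beyond the scatter).

Compound 4 `CC(C(=O)NCc1ccc(C(F)(F)F)cc1-c1ccc(F)c(Cl)c1)c1ccc(NS(C)(=O)=O)c(F)c1` is not yet measured. It differs from compound 3 by 3-chloro-4-fluorophenyl in place of isopentylsulfanyl on an aromatic carbon.

Within the data shown here, two measured steps bear on this exchange, both at the same aromatic carbon: a 3.2-fold lower number from compound 1 to compound 2 (0.51 log units; beyond the scatter) and a 2.8-fold higher number from compound 2 to compound 3 (0.45 log units; beyond the scatter). The (4-fluorobenzyl)oxy group, which carries a six-membered aromatic ring with a fluorine, gives the lowest number of the set, while the azepan-1-yl and isopentylsulfanyl groups, neither of which carries such a ring, lie together. The entering 3-chloro-4-fluorophenyl also brings a six-membered aromatic ring bearing fluorine, so a modest lowering in this assay, of the order seen for compound 2, is expected rather than no change. The estimate is a 1.8-fold lower number from compound 3 to compound 4 (0.24 log units; within the scatter).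

For compound 4 the expected value in this assay is 0.8 nM, with a range from 0.3 nM to 2.5 nM.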

Compound 4, inhibition constant: 0.6 nM
Beside the measured number, compound 4's estimate is 1.3-fold (0.12 log units) above it; the measured number falls inside the stated range.
By their numbers in this assay, from the lowest: compounds 2 and 4 (each within the scatter of the next); then compounds 3 and 1 (each within the scatter of the next).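

In this assay, the six-membered aromatic ring need not be carried by a (4-fluorobenzyl)oxy group, since 3-chloro-4-fluorophenyl on the same aromatic carbon gives a 1.2-fold higher number from compound 2 to compound 4 (0.08 log units; within the scatter) and the two cannot be told apart. Measured against the groups without such a ring, the change gives a 2.3-fold lower number from compound 3 to compound 4 (0.37 log units; beyond the scatter) and also a 2.7-fold lower number from compound 1 to compound 4 (0.43 log units; beyond the scatter), so among these four compounds, with none going against it, the two groups with a halogen-bearing aromatic ring stand apart from azepan-1-yl and isopentylsulfanyl. No measurement shown gives a reason for these steps.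

The compounds shown do not separate the aromatic ring from its halogens, since every ring at this carbon bears fluorine. Going by these compounds, how an unsubstituted phenyl, a pyridine ring or a phenyl carrying a carboxylic acid would stand at this position remains open.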